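Cyclic peroxide series: carboxy chain to alkene

A few compounds are considered here, and "the series" means these few. Any claim that something is new, unique, unknown or untested is made for them only; others in the source may bear on it.

Measured in a functional assay on FM3A cells (Mus musculus) for cytotoxicity (a lower number here means that less compound is needed, a higher number that more compound is needed for the effect), so far:
- compound 1 `C=C(C)COOC1(OOC)CCCCCCCCCCC1` gives 17000 nM
- compound 2 `CCOC(C)OOC1(OOC)CCCCCCCCCCC1` gives 12000 nM
- compound 3 `COOC1(OOCCCCCC(=O)O)CCCCCCCCCCC1` gives 14000 nM

Compound 3 (14000 nM) lies within the scatter of both other compounds. The change to compound 4 `C=CCCOOC1(OOC)CCCCCCCCCCC1` is vinyl in place of 3-carboxypropyl on a saturated chain carbon, two bonds along the chain from an oxygen. Among the compounds with values here, two measured steps bear on it, both introducing the carboxy chain and both small (a 1.2-fold lower number from compound 1 to compound 3 (0.08 log units; within the scatter)) (a 1.2-fold higher number from compound 2 to compound 3 (0.07 log units; within the scatter)). Compound 1 also carries a chain with a double bond and gives 17000 nM in this assay with no separation from compound 3. An estimated step of a 1.1-fold higher number from compound 3 to compound 4 (0.03 log units; within the scatter) is therefore expected, with no change beyond the scatter. For compound 4 the expected value is 15000 nM (estimated range 9000 nM to 25000 nM).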

Compound 4, half-maximal effective concentration: 6000 nM
Beside the measured number, compound 4's estimate is 2.5-fold (0.40 log units) above it; measured number below the stated range.
By their numbers in this assay, from the lowest: compounds 4, 2, 3 and 1 (each within the scatter of the next, the first and the last beyond it).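

In this assay, within the data shown here, the but-3-en-1-yl chain of compound 4 gives the first steps beyond the scatter, both modest: removal of the carboxy end of the chain (a 2.3-fold lower number from compound 3 to compound 4 (0.37 log units; beyond the scatter)) and allyl in place of 1-methylethenyl (a 2.8-fold lower number from compound 1 to compound 4 (0.45 log units; beyond the scatter)). Against the 1-ethoxyethyl group the change stays within the scatter (a 2.0-fold lower number from compound 2 to compound 4 (0.30 log units; within the scatter)), so a double bond in the chain does not by itself set compound 4 apart from every other compound. No measurement available explains these steps.

On these data alone, whether an amine at the chain end would behave like the carboxylic acid or like the terminal alkene stays open. So does the effect of a longer chain ending in a double bond.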